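The source may report more compounds than this note shows. Statements on the series, on what has been measured and on what is new or still open speak of the compounds shown alone.

Measured compounds:
compound 1 `CCCNc1ccc(NC(=O)c2cc(Cl)ccc2O)c(Cl)c1` — in an ADME assay on A549 cells (Homo sapiens) for cytotoxicity, read by resazurin assay, with a stated time of 48 h (on this read-out lower numbers stand for higher toxicity in this test and higher numbers for lower toxicity in this test), compound 1 gives 22500 nM
compound 2 `CCCCCCC(C)Nc1ccc(NC(=O)c2cc(Cl)ccc2O)c(Cl)c1` — compound 2 gives 23500 nM
compound 3 `CCCN(CCC)c1ccc(NC(=O)c2cc(Cl)ccc2O)c(Cl)c1` — compound 3 gives 10700 nM

Compound 1 stands second highest of these three numbers. Compound 2 lies within the scatter of it, a 1.0-fold higher number from compound 1 to compound 2 (0.02 log units; within the scatter), whereas compound 3 gives a lower number, that is, greater toxicity in this test, a 2.1-fold lower number from compound 1 to compound 3 (0.32 log units; beyond the scatter).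

The unmeasured compound 4 `CN(C)c1ccc(CNc2ccc(NC(=O)c3cc(Cl)ccc3O)c(Cl)c2)cc1` differs from compound 1 in one place: 4-(dimethylamino)phenyl in place of ethyl on a saturated chain carbon bound to a nitrogen on an aromatic ring. Among the measured compounds shown here, two measured steps bear on this. The step from compound 1 to compound 2 also swaps the group carried on that nitrogen and stayed within the scatter. The step from compound 1 to compound 3 instead adds a group to that nitrogen and gave a modest drop. Compound 4 swaps rather than adds, so the first step is the closer guide, and a step no larger than the scatter is expected in this assay, if anything toward lower numbers: a 1.3-fold lower number from compound 1 to compound 4 (0.10 log units; within the scatter). Compound 4 is therefore estimated at 18000 nM, within a range from 7000 nM to 45000 nM.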

Compound 4, half-maximal cytotoxic concentration: 24500 nM
Beside the measured number, compound 4's estimate is 1.4-fold (0.13 log units) below it; low and high end bracket the measured number.
By their numbers in this assay, from the lowest: compound 3; then compounds 1, 2 and 4 (each within the scatter of the next).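

Up to this point, the groups on this nitrogen were saturated chains only. Compound 4 places a 4-(dimethylamino)phenyl on the chain carbon, bringing in a six-membered aromatic ring and a hydrogen-bond acceptor, yet in this assay the result stays within the scatter (a 1.1-fold higher number from compound 1 to compound 4 (0.04 log units; within the scatter)). Among the compounds shown here, this position therefore accepts a much larger group carrying an aromatic ring without a measurable shift in this test, and the addition of a second propyl to the nitrogen remains the only change here that goes beyond the scatter (a 2.1-fold lower number from compound 1 to compound 3 (0.32 log units; beyond the scatter)). Nothing in these data explains why the larger group leaves the number unmoved.

Still open, from the compounds shown here alone, is whether a carboxylic acid or a primary amine at the end of the chain would give a similar result. Whether a ring placed directly on the nitrogen would do the same is also unanswered.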